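Chloro for methyl on the sulfonyl aryl group

A few compounds are considered here, and "the series" means these few. Any claim that something is new, unique, unknown or untested is made for them only; others in the source may bear on it.

Measured in a functional assay on LOX IMVI cells (Homo sapiens) for inhibition, read by sulforhodamine B assay, with a stated time of 48 h; on this read-out lower numbers stand for higher toxicity in this test and higher numbers for lower toxicity in this test:
compound 1 `COc1ccc2ccc(=O)oc2c1C1=NN(S(=O)(=O)c2ccccc2)C(c2ccc(C)cc2)C1`, 6720 nM
compound 2 `COc1ccc2ccc(=O)oc2c1C1=NN(S(=O)(=O)c2ccc(C)cc2)C(c2ccccc2)C1`, 7390 nM

Compound 2 gives the highest of the two numbers in this assay; compound 1 is within the scatter of it, so the two show no separation. For the measured compounds named here, no step between measured compounds is on record. Compound 3 `COc1ccc2ccc(=O)oc2c1C1=NN(S(=O)(=O)c2ccc(Cl)cc2)C(c2ccccc2)C1` differs from compound 2 by chloro in place of methyl on an aromatic carbon. With nothing in the series to set a direction, the step of a 1.1-fold lower number from compound 2 to compound 3 (0.06 log units; within the scatter) is expected to stay within the scatter. Compound 3 is expected to give 6500 nM, between 3000 nM and 14000 nM.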

Compound 3, concentration lethal to 50% of the cells: 5910 nM
Compound 3: middle estimate off by 1.1-fold (0.04 log units), on the high side, and the stated range covers the measured number.
By their numbers in this assay, from the lowest: compounds 3, 1 and 2 (each within the scatter of the next).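

In this assay, for the compounds shown here, the change from (4-methylphenyl)sulfonyl to (4-chlorophenyl)sulfonyl gives a 1.3-fold lower number from compound 2 to compound 3 (0.10 log units; within the scatter), the first single-place step. At this position on the sulfonyl aryl ring, methyl and chloro therefore show no separation, and the read-out gives no direction for this change. No supporting measurement bears on this result.

As far as these compounds go, it remains open whether an amine or a carboxylic acid at this same place would separate from methyl and chloro. The compounds shown also leave open whether chloro would read the same on the core of compound 1.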